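From compound 3 to its fluoro analogue

The source may hold more compounds than are shown below. What is called first, only, known or untested is meant among the compounds shown, and "the series" means these compounds.

Values measured so far in a functional assay on CCRF-CEM cells (Homo sapiens) for inhibition, read by MTT assay, with a stated time of 72 h (a higher number here means a weaker inhibitor, a lower number a stronger inhibitor), are as follows
compound 1 `COc1cccc(/C=C/C(=O)Nc2cc(OC)c(OC)c(OC)c2)c1` gives 23400 nM
compound 2 `COc1cc(NC(=O)/C=C/c2cccc(OCc3ccccc3)c2)cc(OC)c1OC` gives 17300 nM
compound 3 `C=C(Br)C(=O)Nc1cccc(/C=C/C(=O)Nc2ccccc2)c1` gives 190 nM

Compound 3 holds the lowest of the three numbers, and its distance to both others lies well beyond the scatter. Compound 4 `C=C(Br)C(=O)Nc1cccc(/C=C/C(=O)Nc2cccc(F)c2)c1` is compound 3 with fluoro in place of hydrogen on an aromatic carbon, meta to a large group (fluoro in place of hydrogen on an aromatic carbon), which reads as phenyl to 3-fluorophenyl.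

Within the data shown here, no measured step covers this exchange. Among the measured compounds shown here, the only step available, a 1.4-fold lower number from compound 1 to compound 2 (0.13 log units; within the scatter) for phenyl in place of hydrogen on a saturated chain carbon bound to an oxygen on an aromatic ring, sits at another place on other compounds. It gives no size for fluoro and serves only as a weak guide, as a single-place change that stayed within the scatter.

In this assay no step beyond the scatter is therefore expected, and the estimate stays anchored on compound 3 at 190 nM with a generous range. The expected change is a 1.1-fold lower number from compound 3 to compound 4 (0.02 log units; within the scatter) and would not exceed the scatter. Compound 4 is expected at 180 nM within an estimated range of 80 nM to 420 nM in this assay once measured.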

Compound 4, half-maximal inhibitory concentration: 26000 nM
The estimate for compound 4 lay 140-fold (2.16 log units) below the measured number; measured number outside the range, above it.
By their numbers in this assay, from the lowest: compound 3; then compounds 2, 1 and 4 (each within the scatter of the next).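

In this assay, the aromatic carbon meta to a large group on the anilino ring proves highly sensitive to substitution: an exchange of hydrogen for fluoro, adding 1 heavy atom, gives a 140-fold higher number from compound 3 to compound 4 (2.14 log units; beyond the scatter). Among these compounds, the earlier single-place change, a 1.4-fold lower number from compound 1 to compound 2 (0.13 log units; within the scatter), involved a far larger added group at another place on other compounds, so the small size of the fluoro exchange offers no assurance that a step will stay small. No available measurement bears on why the number moves so far at this position, and the result itself records only the size and direction of the step.

The compounds shown leave open whether this step is specific to fluoro or would follow any replacement of hydrogen at this carbon, a question that chloro, methyl or an amine at the same place could address. Also open, from the compounds shown here alone, is whether a carboxylic acid or a methoxy group here would give a number closer to that of compound 3 or one closer to that of compound 4.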